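This account rests on a few compounds, and the source may have more. Where it says the series, first, only, none or still open, it means among the compounds named here.

Three compounds share one core: an aromatic ring of carbon only, carrying a side chain and, on a neighbouring aromatic carbon, a second small aromatic ring that changes from compound to compound. Compound 1 `c1cnc(-c2ccccc2OCC2=NCCN2)nc1` carries pyrimidin-2-yl there, and in a functional assay for activation of Alpha-1B adrenergic receptor (Homo sapiens), read by calcium flux (on this read-out higher numbers stand for an effect only at larger amounts of compound and lower numbers for an effect already at smaller amounts), compound 1 reaches only a limit of the assay, < 100000 nM (the limit of < 100000 nM in this assay, at which 1 of the 3 values shown sits). Compound 2 `c1ccc(-c2cnccn2)c(OCC2=NCCN2)c1` carries pyrazin-2-yl instead, and in this assay compound 2 gives 631 nM. Compound 3 `c1coc(-c2ccccc2OCC2=NCCN2)c1` carries furan-2-yl, and in this assay compound 3 gives 10 nM. The steps a step that the limit leaves unreadable from compound 1 to compound 2 and a step that the limit leaves unreadable from compound 1 to compound 3 cannot be sized because the limit of < 100000 nM in this assay, at which 1 of the 3 values shown sits, hides their starting point. The step of a 63-fold lower number from compound 2 to compound 3 (1.80 log units; beyond the scatter) is large and clearly beyond the scatter, so compound 3 stands lowest of the two readable numbers, with compound 2 as its nearest neighbour.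

Compound 4 `c1csc(-c2ccccc2OCC2=NCCN2)c1` differs from compound 3 in one place: thiophen-2-yl in place of furan-2-yl on an aromatic carbon. Within the data shown here, both rings are five-membered with one hetero atom, no donor and one acceptor; only that atom changes, oxygen leaving and sulfur entering. Among the measured compounds shown here, no measured step exchanges one such ring for another; the only readable step, a 63-fold lower number from compound 2 to compound 3 (1.80 log units; beyond the scatter), swaps a six-membered ring with two hetero atoms for furan-2-yl, a far greater change. For compound 4 a step within the scatter is therefore expected, a 1.3-fold lower number from compound 3 to compound 4 (0.10 log units; within the scatter). Compound 4 is estimated at 8 nM, between 2 nM and 40 nM.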

Compound 4, half-maximal effective concentration: 3.98 nM
Beside the measured number, compound 4's estimate is 2.0-fold (0.30 log units) above it, and the stated range covers the measured number.
By their numbers in this assay, from the lowest: compound 4; then compound 3; then compound 2.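

In this assay, changing only the hetero atom of the five-membered ring, with sulfur taking the place of oxygen, gives a 2.5-fold lower number from compound 3 to compound 4 (0.40 log units; beyond the scatter) and so shows that this position responds even to a small exchange, one that leaves the ring size and the counted heavy atoms, donors and acceptors unchanged. Set against the six-membered pyrazin-2-yl ring, thiophen-2-yl gives a 160-fold lower number from compound 2 to compound 4 (2.20 log units; beyond the scatter) and is the largest readable step so far at this place on the six-membered aromatic ring, which leaves compound 4 with the lowest readable number, beyond the scatter from both compound 2 and compound 3. Among these compounds, the steps that start from compound 1, including the one to compound 4, cannot be read, because compound 1 stands at a limit of the assay: the limit of < 100000 nM in this assay, at which 1 of the 4 values shown sits.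

Every group shown at this position is an aromatic ring, so how an amine, a carboxylic acid or a longer chain would read here remains open. From the compounds shown here alone, it is also open whether the step from furan-2-yl to thiophen-2-yl would recur between furan-3-yl and thiophen-3-yl, and the numbers alone do not say what lies behind it.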